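Carbamoyl side-chain variation on the shared core

The compounds below may be only part of what the source reports. "The series", "measured", "known", "first", "only" and "open" are said of these compounds alone.

Compound 2 `CCOC(=O)NC(=O)NC1=CS(=O)(=O)O[C@@]12[C@@H](CO[Si](C)(C)C(C)(C)C)O[C@@H](n1cc(C)c(=O)n(C)c1=O)[C@@H]2O[Si](C)(C)C(C)(C)C` gives 14000 nM in a functional assay on HEL cells (Homo sapiens) (on this read-out lower numbers stand for higher toxicity in this test and higher numbers for lower toxicity in this test), the lowest of the two numbers measured there. Compound 1 `Cc1cn([C@@H]2O[C@H](CO[Si](C)(C)C(C)(C)C)[C@@]3(OS(=O)(=O)C=C3NCC(=O)O)[C@H]2O[Si](C)(C)C(C)(C)C)c(=O)n(C)c1=O` gives 136000 nM in this assay, and the step of a 9.7-fold lower number from compound 1 to compound 2 (0.99 log units; beyond the scatter). Compound 3 `Cc1cn([C@@H]2O[C@H](CO[Si](C)(C)C(C)(C)C)[C@@]3(OS(=O)(=O)C=C3NCC(=O)OCc3ccccc3)[C@H]2O[Si](C)(C)C(C)(C)C)c(=O)n(C)c1=O` reaches only the assay limit of > 200000 nM in this assay. The step of an at least 14-fold higher number from compound 2 to compound 3 (1.15 log units; beyond the scatter), and this is the one case at the limit of > 200000 nM in this assay, at which 1 of the 3 values shown sits.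

Compound 4 `Cc1cn([C@@H]2O[C@H](CO[Si](C)(C)C(C)(C)C)[C@@]3(OS(=O)(=O)C=C3NC(=O)NC(=O)c3ccccc3)[C@H]2O[Si](C)(C)C(C)(C)C)c(=O)n(C)c1=O` carries phenyl in place of ethoxy on a carbonyl carbon. For the measured compounds named here, no measured step changes this group; the steps from compound 1 and to compound 3 each replace the whole nitrogen substituent, so they give only the scale of what such changes have done here. For compound 4 a small shift is expected, a 1.4-fold higher number from compound 2 to compound 4 (0.15 log units; within the scatter). Compound 4 is therefore estimated at 20000 nM, within 5000 nM to 80000 nM.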

Compound 4, half-maximal cytotoxic concentration: >= 200000 nM
Compound 4 ended at the assay's limit (the forecaster's own chance of this, stated with the estimate: 10%); middle value at least 10-fold (1.00 log units) away from the limit.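

On this carbonyl carbon, phenyl in place of ethoxy gives an at least 14-fold higher number from compound 2 to compound 4 (1.15 log units; beyond the scatter), so in this assay the lower number of the (ethoxycarbonyl)carbamoyl group does not carry over to benzoylcarbamoyl, although both keep the carbamoyl link. Against carboxymethyl the change gives an at least 1.4-fold higher number from compound 1 to compound 4 (0.16 log units; that floor lies within the scatter), which is not separated from the scatter, and the step involving compound 3 cannot be read. Compound 4 stands only as a limit: the limit of >= 200000 nM in this assay, at which 1 of the 4 values shown sits.

Going by these compounds, how far the number depends on the ethoxy group itself stays open. A methoxy group, a longer alkoxy chain or an amine on this carbonyl carbon would test that.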